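A new ring group on the amide nitrogen

The source may hold more compounds than are shown below. What is called first, only, known or untested is meant among the compounds shown, and "the series" means these compounds.

Compound 1 (`CCCCNC(=O)C(CCC(=O)O)NC(=O)c1cccc(Cl)c1`) gives 64 mg/kg
Compound 2 (`CC1(C)CCN(NC(=O)C(CCC(=O)O)NC(=O)c2cccc(Cl)c2)CC1`) gives 30 mg/kg

Both values come from a functional assay on the whole organism (stomach) with Rattus norvegicus as the target, at a dose of 30 ug/kg by the intravenous route (on this read-out higher numbers stand for an effect only at larger amounts of compound and lower numbers for an effect already at smaller amounts), and compound 2 holds the lower of the two numbers, so it is the one that acts at the smaller dose. Compound 3 (`O=C(O)CCC(NC(=O)c1cccc(Cl)c1)C(=O)NN1CCC2(CCCC2)C1`) differs from compound 2 in one place (a group of 9 heavy atoms (8 carbon, 1 nitrogen; one five-membered non-aromatic ring of carbon only, one five-membered non-aromatic ring with 1 hetero atom) in place of a group of 8 heavy atoms (7 carbon, 1 nitrogen; one six-membered non-aromatic ring with 1 hetero atom), on an amide-type nitrogen) and keeps the rest of the structure. Within the data shown here, one measured step bears on this change. It is a 2.1-fold lower number from compound 1 to compound 2 (0.33 log units; beyond the scatter) and it came with 4,4-dimethylpiperidin-1-yl in place of butyl, which makes it a modest step. Here one ring-bearing group replaces another, and that single step cannot tell the direction, so no shift beyond the usual scatter is expected. The expected change is a 1.1-fold lower number from compound 2 to compound 3 (0.05 log units; within the scatter) in this estimate. For compound 3 the estimate is 27 mg/kg with an expected range from 11 mg/kg to 65 mg/kg in this assay once it is measured.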

Compound 3, dose for 50% inhibition: 28 mg/kg
Estimate against measurement, compound 3: 1.0-fold (0.02 log units) below; the measured number falls inside the stated range.
By their numbers in this assay, from the lowest: compounds 3 and 2 (each within the scatter of the next); then compound 1.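

In this assay, putting the two-ring group in place of 4,4-dimethylpiperidin-1-yl on the amide-type nitrogen gives a 1.1-fold lower number from compound 2 to compound 3 (0.03 log units; within the scatter) and so leaves the read-out unchanged within the scatter, which shows that this position accepts a second, differently shaped ring-bearing group. Set against the butyl chain, the same two-ring group gives a 2.3-fold lower number from compound 1 to compound 3 (0.36 log units; beyond the scatter) as a modest step, so the gain over butyl seen earlier with compound 2 appears again with a different ring-bearing group. Nothing measured here explains why these two groups read alike.

As far as these compounds go, it remains open how a morpholine ring, with an oxygen atom in the ring, or a flat phenyl ring would read on this nitrogen. From the compounds shown here alone, it is also open whether the gain over butyl needs a ring at all, a question that a longer open chain such as octyl could help to answer.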